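The compounds below may be only part of what the source reports. "The series", "measured", "known", "first", "only" and "open" are said of these compounds alone.

Measured in a functional assay on U-87MG ATCC cells (Homo sapiens) for antiproliferative activity; on this read-out higher numbers stand for weaker inhibition and lower numbers for stronger inhibition:
- compound 1 `Cc1c2c(n3c1CCCNC[C@H](C)Nc1cc-3ccc1C(N)=O)CC(C)(C)CC2=O`: 366 nM
- compound 2 `COCCC(=O)N1CCCc2c(C)c3c(n2-c2ccc(C(N)=O)c(c2)N[C@@H](C)[C@@H]1C)CC(C)(C)CC3=O`: 80 nM
- compound 3 `CC[C@H](N)C(=O)N1CCc2c(C)c3c(n2-c2ccc(C(N)=O)c(c2)N[C@@H](C)[C@H](C)C1)CC(C)(C)CC3=O`: 45 nM

Compound 3 lies within the scatter of compound 2, and its number is lower than that of compound 1, a gap beyond the scatter.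

Compound 4 `Cc1c2c(n3c1CCN(C(=O)[C@@H](O)C(C)C)C[C@@H](C)[C@H](C)Nc1cc-3ccc1C(N)=O)CC(C)(C)CC2=O` has 1-hydroxy-2-methylpropyl in place of 1-aminopropyl on a carbonyl carbon.

Among the compounds with values here, no measured pair isolates this change. Compound 2, which also has a carbonyl on an amide-type nitrogen in a ring, with a different chain on it, gives 80 nM. A small rise in the number is therefore expected, toward weaker inhibition and within the scatter, with the estimated step of a 1.8-fold higher number from compound 3 to compound 4 (0.25 log units; within the scatter).

For compound 4 the estimated value is 80 nM, with an expected range of 30 nM to 220 nM.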

Compound 4, half-maximal inhibitory concentration: 76 nM
The estimate for compound 4 lay 1.1-fold (0.02 log units) above the measured number; low and high end bracket the measured number.
By their numbers in this assay, from the lowest: compounds 3, 4 and 2 (each within the scatter of the next); then compound 1.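

On a carbonyl carbon whose other neighbour is the amide-type nitrogen in a ring, in this assay 1-hydroxy-2-methylpropyl in place of 1-aminopropyl gives a 1.7-fold higher number from compound 3 to compound 4 (0.23 log units; within the scatter), so the nitrogen of the 1-aminopropyl group is not needed to keep the number at this level. The swap also shows that this place accepts a chain with one more heavy atom. Nothing available explains why the two groups read alike.

The swap changes both the heteroatom and the branching, and these cannot be separated here. On these data alone, a plain 2-methylpropyl group or a carboxylic acid at this place remains open.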